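Swapping the benzyl group: half-life notes on compound 3

The source may report more compounds than this note shows. Statements on the series, on what has been measured and on what is new or still open speak of the compounds shown alone.

In an in vitro ADME assay on microsomes from liver (Homo sapiens) for metabolic stability, tested at 1 uM (on this read-out higher numbers stand for a longer-lived compound and lower numbers for a shorter-lived compound), compound 1 `CS(=O)(=O)Nc1ccc2c(c1)S(=O)(=O)N=C(C1=C(O)[C@@H]3[C@H]4CC[C@H](C4)[C@@H]3N(Cc3ccccc3F)C1=O)N2` gives > 1 h, which is a limit of the assay and not a number. Compound 2 `CS(=O)(=O)Nc1ccc2c(c1)S(=O)(=O)N=C(C1=C(O)[C@@H]3[C@H]4CC[C@H](C4)[C@@H]3N(Cc3ccccc3Cl)C1=O)N2` gives > 1 h, also a limit. The evidence so far is the limit of > 1 h in this assay, at which 2 of the 2 values shown sit. Among the compounds with values here, the one measured step is a step that the two limits leave unreadable from compound 1 to compound 2, and it offers no size to carry forward.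

Compound 3 `COc1cccc(CN2C(=O)C(C3=NS(=O)(=O)c4cc(NS(C)(=O)=O)ccc4N3)=C(O)[C@@H]3[C@H]4CC[C@H](C4)[C@@H]32)c1` has 3-methoxyphenyl in place of 2-chlorophenyl on a saturated chain carbon bound to an amide-type nitrogen in a ring. Within the data shown here, no measured step covers this change, and neither direction can be read from the data.

In this assay, the expected step is therefore none beyond the scatter, and a number no higher from compound 2 to compound 3 (the limit leaves the size open) is estimated as small. The estimate for compound 3 is 1 h, with an expected range of 0.4 h to 2 h.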

Compound 3, half-life: > 1 h
Compound 3: only a limit was reported; the forecaster's own chance of this, stated with the estimate: 65%; the middle value sits exactly at the limit.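

In this assay compound 3 gives > 1 h, a limit of the assay and not a number. Within the data shown here, no step among compound 1, compound 2 and compound 3 can be read. The compounds shown leave open how their half-lives compare and whether swapping the benzyl group changes them at all: the limit of > 1 h in this assay, at which 3 of the 3 values shown sit.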